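Chloro to Methyl: Expected Effect on Cell Growth Inhibition

A few compounds are considered here, and "the series" means these few. Any claim that something is new, unique, unknown or untested is made for them only; others in the source may bear on it.

Compound 1 `COc1cc(-c2nccn3cc(-c4ccc(N)cc4)nc23)cc(OC)c1OC`: 294 nM
Compound 2 `COc1cc(-c2nccn3cc(-c4ccc(Cl)cc4)nc23)cc(OC)c1OC`: 2090 nM

Both were tested in a functional assay on MDA-MB-231 cells (Homo sapiens) for inhibition, read by MTT assay, with a stated time of 48 h; on this read-out lower numbers stand for stronger inhibition and higher numbers for weaker inhibition. Among the measured compounds shown here, compound 2 stands highest of the two numbers; the only known step, a 7.1-fold higher number from compound 1 to compound 2 (0.85 log units; beyond the scatter), separates it from compound 1. Compound 3 `COc1cc(-c2nccn3cc(-c4ccc(C)cc4)nc23)cc(OC)c1OC` differs from compound 2 by methyl in place of chloro on an aromatic carbon. For the measured compounds named here, no measured step exchanges chloro for methyl; the one known step concerns amino to chloro and is modest. Both chloro and methyl carry no hydrogen-bond donors or acceptors, and a step within the scatter in this assay is expected. Compound 3 is therefore estimated at 1800 nM, ranging from 700 nM to 4500 nM, a step of a 1.2-fold lower number from compound 2 to compound 3 (0.06 log units; within the scatter).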

Compound 3, half-maximal inhibitory concentration: 53 nM
The estimate for compound 3 lay 34-fold (1.53 log units) above the measured number; the measured number lies below the stated range.
By their numbers in this assay, from the lowest: compound 3; then compound 1; then compound 2.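

In this assay, swapping chloro for methyl on this aromatic carbon gives a 39-fold lower number from compound 2 to compound 3 (1.60 log units; beyond the scatter) even though the two groups match in heavy-atom count and hydrogen-bond donors and acceptors, so those counts alone do not predict the result at this position. Methyl also outperforms amino here, with a 5.5-fold lower number from compound 1 to compound 3 (0.74 log units; beyond the scatter) as the step, placing 4-methylphenyl first among the three groups. No measurement available here explains these differences. On these data alone, whether an ethyl or methoxy group at this position would give a still lower number remains open.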